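Ethylamino to dimethylamino exchange across two cores

The compounds below may be only part of what the source reports. "The series", "measured", "known", "first", "only" and "open" are said of these compounds alone.

Compound 1 `C=C(c1ccc(OC)cc1NC(=O)CNCC)c1ccc(OC)c2c1OC(C)(C)C=C2` and compound 3 `C=C(c1ccc(OC)cc1NC(=O)CN(C)C)c1ccc(OC)c2c1OC(C)(C)C=C2` share one core; compound 2 `C=C(c1cc(OC)c(OC)c(OC)c1)c1ccc(OC)cc1NC(=O)CNCC` and compound 4 `C=C(c1cc(OC)c(OC)c(OC)c1)c1ccc(OC)cc1NC(=O)CN(C)C` share another. How the core of compound 1 and the core of compound 2 differ is not broken down here. In a functional assay on HeLa cells (Homo sapiens) for antiproliferative activity, read by MTT assay, with a stated time of 48 h (on this read-out lower numbers stand for stronger inhibition and higher numbers for weaker inhibition), compound 1 gives 1090 nM, compound 3 gives 900 nM and compound 2 gives 430 nM. Of the three measured compounds compound 2 carries the lowest number, and its gaps to compound 3 and to compound 1 are both beyond the scatter. Compound 3 arises from compound 1 by dimethylamino in place of ethylamino on a saturated chain carbon bound to a carbonyl carbon; the step reads a 1.2-fold lower number from compound 1 to compound 3 (0.08 log units; within the scatter). Compound 4 arises from compound 2 by the same change, (dimethylamino in place of ethylamino on a saturated chain carbon bound to a carbonyl carbon), at the same place in both pairs. Since the change on the core of compound 1 gave a 1.2-fold lower number from compound 1 to compound 3 (0.08 log units; within the scatter), for compound 4 a step of about a 1.2-fold lower number from compound 2 to compound 4 (0.08 log units; within the scatter) is expected, again within the scatter. Compound 4 is therefore estimated at 360 nM in this assay, with a range from 180 nM to 800 nM covering the uncertainty.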

Compound 4, half-maximal inhibitory concentration: 370 nM
For compound 4 the middle estimate is 1.0-fold (0.01 log units) below the measured one, and the stated range covers the measured number.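

In this assay the new step reads a 1.2-fold lower number from compound 2 to compound 4 (0.07 log units; within the scatter) and, set beside the earlier step, the exchange reads alike on the two cores: the same change on two cores in this assay, a 1.2-fold lower number (0.08 log units; within the scatter) from compound 1 to compound 3 and a 1.2-fold lower number (0.07 log units; within the scatter) from compound 2 to compound 4, 1.0-fold (0.02 log units) apart, within the scatter of two such steps.

On these two cores, then, dimethylamino in place of ethylamino on a saturated chain carbon bound to a carbonyl carbon leaves the number within the scatter, and the step read on one core carries over to the other. This rests on a single pair of cores and on a change that moves the number little on either of them. It does not show how the exchange would read on a third core, or whether a step beyond the scatter would carry over equally well.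

Still open, as far as these compounds go, is how other groups at this place would read, such as a primary amine, a cyclic amine like pyrrolidine or morpholine, or a longer chain like propylamino. Also open, from the compounds shown here alone, is whether the same agreement between cores would hold in other cell lines.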